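The compounds below may be only part of what the source reports. "The series", "measured", "known", "first", "only" and "open" are said of these compounds alone.

Working notes on the series. Of the compounds shown here, three have been measured on a shared core: compound 1 `COc1cc2c(cc1OC)C(CC(=O)O)CC2`, compound 2 `COc1cc2c(cc1OC)C(CC(N)=O)CC2` and compound 3 `COc1cc2c(cc1OC)C(CC(=O)NC(C)C)CC2`. In a functional assay on the whole organism (strain Wistar) for inhibition, with Rattus norvegicus as the target, read by paw edema, with stated times of 60 min and 2 h, at a dose of 100 mg/kg by the oral route (a lower number here means less inhibition, a higher number more inhibition at the dose given (going by the name of the read-out)), compound 1 gives 24%, compound 2 gives 31% and compound 3 gives 37%, the highest of the three numbers; the steps are a number 13 percentage points higher from compound 1 to compound 3 (beyond the scatter) and a number 6 percentage points higher from compound 2 to compound 3 (within the scatter). The next candidate is compound 4 `COc1cc2c(cc1OC)C(CC(=O)NC1CCCCC1)CC2`, differing from compound 3 by cyclohexyl in place of isopropyl on an amide-type nitrogen. For the measured compounds named here, the only measured step at this nitrogen is a number 6 percentage points higher from compound 2 to compound 3 (within the scatter), within the scatter, and a number 7 percentage points higher from compound 1 to compound 2 (within the scatter) is also within it. Nothing measured speaks for a larger effect of a bigger group on the amide nitrogen, so a step within the scatter, a number 3 percentage points higher from compound 3 to compound 4 (within the scatter), is expected in this assay. Compound 4 is therefore estimated at 40%, between 28% and 52%.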

Compound 4, a percentage reported as inhibition, in the whole organism at one dose (the size of the read-out at that dose, not a potency): 56%
Estimate against measurement, compound 4: 16 percentage points below; the whole stated range lies below it.
By their numbers in this assay, from the lowest: compounds 1, 2 and 3 (each within the scatter of the next, the first and the last beyond it); then compound 4.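

For the compounds shown here, on the amide-type nitrogen, cyclohexyl in place of isopropyl gives a number 19 percentage points higher from compound 3 to compound 4 (beyond the scatter) in this assay and is the first change of the group on this nitrogen to give a step beyond the scatter from compound 3, since the step from the amide hydrogen to isopropyl stayed within it. Going by these compounds alone, measured against the amide hydrogen, cyclohexyl gives a number 25 percentage points higher from compound 2 to compound 4 (beyond the scatter) and, against the hydroxy on the carbonyl carbon, cyclohexylamino gives a number 32 percentage points higher from compound 1 to compound 4 (beyond the scatter) and so the group on this nitrogen counts for more than the earlier compounds showed. Nothing available explains the size of these steps. Whether the ring itself or the carbon count lies behind the result stays open: an open n-hexyl chain, a cyclopentyl ring or a phenyl ring on this nitrogen would separate the two.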